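The source may report more compounds than this note shows. Statements on the series, on what has been measured and on what is new or still open speak of the compounds shown alone.

Compound 1 `Cc1ccc2cc(C(C)N(Cc3ccc(F)cc3)Cc3ccc(C(C)C)cc3)c(=O)[nH]c2c1` and compound 2 `Cc1ccc2cc(CN(Cc3ccc(F)cc3)Cc3ccc(C(C)C)cc3)c(=O)[nH]c2c1` share one core, while compound 3 `Cc1ccc2[nH]c(=O)c(CN(Cc3ccc(OC(F)F)cc3)Cc3ccc(C(C)(C)C)cc3)cc2c1` and compound 4 `CCc1ccc2[nH]c(=O)c(CN(Cc3ccc(OC(F)F)cc3)Cc3ccc(C(C)(C)C)cc3)cc2c1` share another; the difference between the two cores is not broken down here. In a toxicity assay on MDCK cells (Canis lupus familiaris) for cytotoxicity, read by crystal violet staining, with a stated time of 48 h (on this read-out higher numbers stand for lower toxicity in this test and lower numbers for higher toxicity in this test), compound 1 gives > 33000 nM, which is a limit of the assay rather than a number. In this assay compound 2 also gives > 33000 nM, again a limit. In this assay compound 3 gives > 5000 nM, once more a limit. The change from compound 2 to compound 1, (methyl in place of hydrogen on a saturated chain carbon bound to an amine nitrogen and an aromatic carbon), made a step that the two limits leave unreadable from compound 2 to compound 1, whose size cannot be read because the limit of > 33000 nM in this assay, at which 2 of the 3 values shown sit, holds both values. The change from compound 3 to compound 4, (methyl in place of hydrogen on a saturated chain carbon bound to an aromatic carbon), is the same kind of change, though here the saturated chain carbon is bound to an aromatic carbon only and not also to an amine nitrogen. Compound 4 is estimated at 30000 nM in this assay, between 8000 nM and 100000 nM. The expected step that the limit leaves unreadable from compound 3 to compound 4 is estimated to be small, and this expectation rests on compound 3 sitting at the limit of > 5000 nM in this assay, at which 1 of the 3 values shown sits, and on a step that the two limits leave unreadable from compound 2 to compound 1 showing nothing readable.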

Compound 4, half-maximal cytotoxic concentration: > 5000 nM
Compound 4 was reported as a limit (the forecaster's own chance of this, stated with the estimate: 85%); the middle value does not contradict the limit.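

No new step can be read between compound 3 and compound 4 in this assay, because both values are limits and not numbers: the limit of > 5000 nM in this assay, at which 2 of the 4 values shown sit.

The compounds shown leave open whether methyl in place of hydrogen, on either kind of saturated chain carbon, changes toxicity in this assay at all, and how far each compound's real value lies from its limit.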